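Working notes: methoxy in place of trifluoromethyl across two cores

The compounds below may be only part of what the source reports. "The series", "measured", "known", "first", "only" and "open" are said of these compounds alone.

Compound 1 `COc1cccc(NC(=O)c2cc(=O)[nH]c3cc(Br)ccc23)c1` gives > 20000 nM in a functional assay on KYSE-410 cells (Homo sapiens) for antiproliferative activity, read by MTT assay, with a stated time of 72 h (a higher number here means a weaker inhibitor, a lower number a stronger inhibitor), a limit of the assay rather than a number.
Compound 2 `O=C(Nc1cccc(C(F)(F)F)c1)c1cc(=O)[nH]c2cc(Br)ccc12` gives > 20000 nM in this assay, also a limit.
Compound 3 `O=C(Nc1cc(F)cc(F)c1)c1cc(=O)[nH]c2cc(C(F)(F)F)ccc12` gives 17900 nM in this assay.

Two of the three values sit at the limit (the limit of > 20000 nM in this assay, at which 2 of the 3 values shown sit); compound 3 alone gives a number. Compound 1 and compound 2 share one core; compound 3 has a different core, and the difference between the two cores is not broken down here. From compound 2 to compound 1 the change is methoxy in place of trifluoromethyl on an aromatic carbon, and the step that the two limits leave unreadable from compound 2 to compound 1 cannot be read from two limits.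

Compound 4 `COc1ccc2c(C(=O)Nc3cc(F)cc(F)c3)cc(=O)[nH]c2c1` makes the same kind of change from compound 3, (methoxy in place of trifluoromethyl on an aromatic carbon). The place is not the same: in compound 4 the carbon belongs to a fused or bridged system of two rings, meta to a fused ring and para to a fused ring, whereas in compound 1 it is meta to a large group. The measured pair gives no size for this change, so the expectation for compound 4 rests only on compound 3 at 17900 nM. The step is expected to be a 1.1-fold higher number from compound 3 to compound 4 (0.05 log units; within the scatter). Compound 4 is estimated at 20000 nM, between 9000 nM and 45000 nM.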

Compound 4, half-maximal inhibitory concentration: > 20000 nM
Compound 4 ended at the assay's limit; the forecaster's own chance of this, stated with the estimate: 55%; the middle value lies on the limit itself.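

Among the compounds shown here, the one readable step for this change is an at least 1.1-fold higher number from compound 3 to compound 4 (0.04 log units; that floor lies within the scatter) in this assay, a floor and not a size. Compound 4 gives > 20000 nM, which is a limit of the assay. The same change on the shared core of compound 1 and compound 2 cannot be read, as both values are limits, and the place of the group on the ring also differs, so the data do not show whether the change carries from one core to the other with a similar effect, and most of the series gives no number to compare: the limit of > 20000 nM in this assay, at which 3 of the 4 values shown sit.

Open, from the compounds shown here alone, is whether a group other than methoxy or trifluoromethyl on this aromatic carbon, such as an amine or a carboxylic acid, would give a number clear of the limit in this assay. Also open, going by these compounds, is how a longer chain in place of methoxy would read on either core.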